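The source may hold more compounds than are shown below. What is called first, only, known or untested is meant among the compounds shown, and "the series" means these compounds.

Compound 1 `NCCCc1c[nH]c2c(F)cccc12` and compound 2 `CCCc1c[nH]c2ccc(F)cc12` share the same core but differ in several places at once. In an assay on isolated protein for inhibition of Myeloperoxidase (Homo sapiens), read by ELISA, with a stated time of 5 min (a lower number here means a stronger inhibitor, a higher number a weaker inhibitor), compound 1 gives 26 nM. For compound 2 this assay reports only a limit, > 100 nM, and not a number. Of the two values shown, one sits at the limit of > 100 nM in this assay, at which 1 of the 2 values shown sits, so compound 2 stands only as a weak inhibitor in this assay, without a known position. Compound 3 `N#CSCCCc1c[nH]c2ccc(F)cc12` differs from compound 2 in a single place: cyanosulfanyl in place of hydrogen on a saturated chain carbon, three bonds along the chain from an aromatic carbon. For the measured compounds named here, no pair of measured compounds here differs in one place, so no measured step guides this change. The step that the limit leaves unreadable from compound 2 to compound 3 is expected to move toward stronger inhibition by a little more than the scatter, but this rests on no measured comparison. Compound 3 is therefore estimated at 150 nM, within a range from 30 nM to 600 nM.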

Compound 3, half-maximal inhibitory concentration: 23 nM
Estimate against measurement, compound 3: 6.5-fold (0.81 log units) above; the whole stated range lies above it.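

In this assay, cyanosulfanyl in place of hydrogen on a saturated chain carbon, three bonds along the chain from an aromatic carbon, gives an at least 4.3-fold lower number from compound 2 to compound 3 (0.63 log units; beyond the scatter). For the compounds shown here, this is the first readable step, and it shows that this chain position accepts the group, with a gain in inhibition beyond the scatter. Compound 2 gives > 100 nM, which is a limit and not a number, so the full size of the step stays unknown because compound 2 has no exact position: the limit of > 100 nM in this assay, at which 1 of the 3 values shown sits.

The compounds shown leave open whether a nitrile, a thiol or a methylthio group on the same chain carbon would give a similar step. They also leave open how an amine at this place, or a longer chain carrying cyanosulfanyl, would read on the core of compound 3.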